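Chloro on the benzothiazole of compound 2: an untested position

The source may report more compounds than this note shows. Statements on the series, on what has been measured and on what is new or still open speak of the compounds shown alone.

The measured compounds share one core and differ only at one aromatic carbon of the benzyl ring. In a functional assay on HCT-116 cells (Homo sapiens) for antiproliferative activity, read by MTT assay, with a stated time of 48 h (on this read-out higher numbers stand for weaker inhibition and lower numbers for stronger inhibition), compound 1 `COc1ccc(CN(C(=O)CSc2nc3ccccc3s2)c2cc(OC)c(OC)c(OC)c2)cc1F` gives 1830 nM. Compound 2 `COc1ccc(CN(C(=O)CSc2nc3ccccc3s2)c2cc(OC)c(OC)c(OC)c2)cc1O` gives 182 nM in this assay, the step being a 10-fold lower number from compound 1 to compound 2 (1.00 log units; beyond the scatter). Compound 3 `COc1ccc(CN(C(=O)CSc2nc3ccccc3s2)c2cc(OC)c(OC)c(OC)c2)cc1C(F)(F)F` reaches only the limit of > 80000 nM in this assay, a limit and not a number, as the limit of > 80000 nM in this assay, at which 1 of the 3 values shown sits, records. The steps of an at least 43-fold higher number from compound 1 to compound 3 (1.64 log units; beyond the scatter) and an at least 430-fold higher number from compound 2 to compound 3 (2.64 log units; beyond the scatter) follow from that limit. Of the two numbers shown, compound 2 has the lowest, with compound 1 nearest.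

Compound 4 `COc1ccc(CN(C(=O)CSc2nc3cc(Cl)ccc3s2)c2cc(OC)c(OC)c(OC)c2)cc1O` differs from compound 2 by chloro in place of hydrogen on an aromatic carbon. Every measured step changes a substituent on the benzyl ring, while this change sits on the fused ring of the thioether side; none of the three steps bears on it directly. No step beyond the scatter is therefore expected, a 1.0-fold lower number from compound 2 to compound 4 (0.00 log units; within the scatter). Compound 4 is estimated at 180 nM in this assay, within the range 60 nM to 600 nM.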

Compound 4, half-maximal inhibitory concentration: 429 nM
For compound 4 the middle estimate is 2.4-fold (0.38 log units) below the measured one; the measured number falls inside the stated range.
By their numbers in this assay, from the lowest: compound 2; then compound 4; then compound 1. At a limit, above all of these: compound 3.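

The fused ring on the thioether side responds to substitution: in this assay, chloro in place of hydrogen gives a 2.4-fold higher number from compound 2 to compound 4 (0.37 log units; beyond the scatter). For the compounds shown here, the earlier steps all lay on the benzyl ring, so this is the first reading of a change outside it, and with the hydroxy group kept, this change costs only a modest part of the activity. The data shown give no measured property that would explain this step.

One substituent at this carbon cannot show whether the rise in the number belongs to chloro itself or to any group placed there, so an amine or a carboxylic acid at the same carbon remains an open comparison. Also open, from the compounds shown here alone, is whether chloro here would give a step of similar size on the fluoro or trifluoromethyl benzyl rings of compound 1 and compound 3.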